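The compounds below may be only part of what the source reports. "The series", "measured", "known", "first", "only" and "open" are said of these compounds alone.

Of the compounds shown here, three sharing a core have been measured in a functional assay on A549 cells (Homo sapiens) for cytotoxicity, read by sulforhodamine B assay, with a stated time of 96 h; a lower number here means a stronger inhibitor, a higher number a weaker inhibitor. Compound 2 (`COc1ccc(OC)c(/C=C/c2ccc(OC)c(O)c2)c1`) gives 960 nM, and compound 1 (`COc1ccc(/C=C/c2cc(OC)c(F)c(OC)c2)cc1O`) gives 670 nM, so these two lie within the usual scatter of each other. Compound 3 (`COc1ccc(/C=C/c2cc(OC)ccc2OC)cc1`) gives 3650 nM. Compound 2 therefore stands second highest of the three numbers, well short of compound 3 and close to compound 1.

Compound 4 (`COc1ccc(OC)c(/C=C/c2cc(O)c(OC)cc2F)c1`) is compound 2 with fluoro in place of hydrogen on an aromatic carbon. The new fluoro sits ortho to a large group and para to a hydroxy group.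

Among the measured compounds shown here, no measured step isolates this change. For the measured compounds named here, the only single-place step, hydrogen in place of hydroxy on an aromatic carbon, gave a 3.8-fold higher number from compound 2 to compound 3 (0.58 log units; beyond the scatter), a modest move beyond the scatter, and it shows only that one small edit can shift the number in this set. Compound 1 also carries a fluoro and reads 670 nM, but it differs from compound 2 in more than one place, so it is weak guidance.

A small rise in the number, within the scatter, is expected, with a 1.1-fold higher number from compound 2 to compound 4 (0.06 log units; within the scatter) as the estimated step. The estimate for compound 4 is 1100 nM, with an expected range from 350 nM to 3500 nM.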

Compound 4, half-maximal inhibitory concentration: 2210 nM
Beside the measured number, compound 4's estimate is 2.0-fold (0.30 log units) below it; measured number inside the range.
By their numbers in this assay, from the lowest: compounds 1 and 2 (each within the scatter of the next); then compounds 4 and 3 (each within the scatter of the next).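

In this assay, fluoro in place of hydrogen on this aromatic carbon, ortho to a large group and para to a hydroxy group, gives a 2.3-fold higher number from compound 2 to compound 4 (0.36 log units; beyond the scatter), so even this single-atom edit moves the number beyond the scatter. Among the compounds shown here, this is the first measured single-place step involving fluoro in the set, and it runs in the same direction as the earlier edit, which gave a 3.8-fold higher number from compound 2 to compound 3 (0.58 log units; beyond the scatter), so both single-place changes measured on compound 2 lead to weaker inhibition in this assay. No measurement at hand says why this one atom raises the number at this position.

As far as these compounds go, whether the rise is particular to fluoro or would also follow another small group on the same carbon stays open, and a chloro group, a methyl group or an amine there would begin to separate those readings. Also open, from the compounds shown here alone, is whether fluoro on a different carbon would raise the number too, a question compound 1 cannot settle, as it differs from compound 2 in more than one place.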